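This account rests on a few compounds, and the source may have more. Where it says the series, first, only, none or still open, it means among the compounds named here.

Of the compounds shown here, three have so far been measured in a functional assay on TK-10 cells (Homo sapiens) for inhibition, read by sulforhodamine B assay, with a stated time of 48 h (on this read-out higher numbers stand for lower toxicity in this test and lower numbers for higher toxicity in this test), and all are built on the same core. Compound 1 `COc1cc(-c2nn(-c3cccc(NC(=O)Nc4cc(C(F)(F)F)cc(C(F)(F)F)c4)c3)cc2-c2ccncc2)ccc1Cl` gives 10100 nM in this assay. Compound 2 `COc1cc(-c2nn(-c3cccc(NC(=O)Nc4ccc(Cl)c(Cl)c4)c3)cc2-c2ccncc2)ccc1Cl` reaches only a limit of the assay, > 50000 nM, so no number stands for it. Compound 3 `O=C(Nc1cccc(-n2cc(-c3ccncc3)c(-c3ccc(Cl)c(O)c3)n2)c1)Nc1ccc(Cl)c(Cl)c1` likewise stops at a limit, > 32500 nM. Between these two, a step that the two limits leave unreadable from compound 2 to compound 3 cannot be read, since both ends are limits the limit of > 32500 nM in this assay, at which 1 of the 3 values shown sits (the limit of > 50000 nM in this assay, at which 1 of the 3 values shown sits). Compound 2 thus stands with the limits, while compound 1 alone gives a number in this assay.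

Compound 4 `COc1cc(-c2nn(-c3cccc(NC(=O)c4ccc(Cl)c(C(F)(F)F)c4)c3)cc2-c2ccncc2)ccc1Cl` differs from compound 2 in one place: 4-chloro-3-(trifluoromethyl)phenyl in place of (3,4-dichlorophenyl)amino on a carbonyl carbon. Among the measured compounds shown here, no measured step alters the carbonyl's neighbour in this way, so none of the measured steps bears directly on the change, and the only readable comparison among the measured compounds exchanges ring substituents instead. With nothing to lean on, the estimate is wide. Compound 4 is expected at 30000 nM, between 8000 nM and 100000 nM. The step this implies is expected to be an at least 1.6-fold lower number from compound 2 to compound 4 (0.22 log units; that floor lies within the scatter).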

Compound 4, concentration lethal to 50% of the cells: > 32500 nM
Compound 4 was reported as a limit; the forecaster's own chance of this, stated with the estimate: 50%; at least 1.0-fold (0.03 log units) between middle value and limit.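

In this assay, among the compounds shown here, compound 4 stops at a limit of the assay, > 32500 nM, and compound 2 also stands at a limit, so no step between them can be read: the limit of > 32500 nM in this assay, at which 2 of the 4 values shown sit. The compounds shown leave open whether 4-chloro-3-(trifluoromethyl)phenyl in place of (3,4-dichlorophenyl)amino changes the read-out at all.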